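Chloro added to the aromatic ring of compound 1

The source may hold more compounds than are shown below. What is called first, only, known or untested is meant among the compounds shown, and "the series" means these compounds.

In an assay for inhibition of HSP60/HSP10 (Homo sapiens), with a stated time of 60 min (a higher number here means a weaker inhibitor, a lower number a stronger inhibitor), compound 1 `COc1ccccc1C(=O)Nc1ccc(Sc2nc3ccccc3s2)cc1` gives only a limit, > 100000 nM, and its standing rests on (the limit of > 100000 nM in this assay, at which 1 of the 2 values shown sits). Compound 2 `O=C(Nc1ccc(Sc2nc3ccccc3s2)cc1)c1cccc(Br)c1O` gives 26000 nM in this assay. Going by the values given here, the single measured step, an at least 3.8-fold lower number from compound 1 to compound 2 (0.58 log units; beyond the scatter), alters the group on the carbonyl carbon. Among the compounds with values here, compound 3 `COc1ccccc1C(=O)Nc1ccc(Sc2nc3ccccc3s2)c(Cl)c1` instead carries chloro in place of hydrogen on an aromatic carbon, a place no measured step touches. Within the data shown here, no step therefore fixes a direction, and no change beyond the scatter is expected in this assay. Compound 3 is expected to give 100000 nM, within 30000 nM to 300000 nM, which means an expected step of a number no higher from compound 1 to compound 3 (the limit leaves the size open).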

Compound 3, half-maximal inhibitory concentration: > 100000 nM
Compound 3 ended at the assay's limit; the forecaster's own chance of this, stated with the estimate: 65%; the middle value lies on the limit itself.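

In this assay compound 3 gives > 100000 nM, a limit. Going by these compounds alone, compound 1 gives > 100000 nM, also a limit, so no step between compound 1 and compound 3 can be read. The compounds shown leave open whether chloro in place of hydrogen on an aromatic carbon shifts the number at all.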